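The source may report more compounds than this note shows. Statements on the series, on what has been measured and on what is new or still open speak of the compounds shown alone.

Three compounds in this set have been put through an ADME assay (liver) for metabolic stability, with Liver microsome (Homo sapiens) as the target, using microsomes and NADPH, with a stated time of 30 min, tested at 1 uM (a lower number here means slower removal, a higher number faster removal of the compound), so far. Compound 3, `Nc1ccc(S(=O)(=O)N2CCN(c3ncc(C(O)(C(F)(F)F)C(F)(F)F)cc3-c3cccnc3)CC2)cn1`, gives 17 mL.min-1.g-1 in this assay, and it is the only one of the three to return an actual number. Compound 1, `Nc1ccc(S(=O)(=O)N2CCN(c3ncc(C(O)(C(F)(F)F)C(F)(F)F)cc3Br)CC2)cn1`, gives only a limit of the assay, < 14 mL.min-1.g-1. Compound 2, `Nc1ccc(S(=O)(=O)N2CCN(c3ncc(C(O)(C(F)(F)F)C(F)(F)F)cc3-c3ccoc3)CC2)cn1`, likewise returns a limit, < 14 mL.min-1.g-1. The step that the two limits leave unreadable from compound 1 to compound 2 therefore cannot be read, and the steps of an at least 1.2-fold higher number from compound 1 to compound 3 (0.08 log units; that floor lies within the scatter) and an at least 1.2-fold higher number from compound 2 to compound 3 (0.08 log units; that floor lies within the scatter) are known only as floors, each small enough to sit inside the usual variation of repeated runs; what sets compound 3 apart is simply that it clears the limit at which the others sit, (the limit of < 14 mL.min-1.g-1 in this assay, at which 2 of the 3 values shown sit).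

Compound 4, `Cc1nc2cc(-c3cc(C(O)(C(F)(F)F)C(F)(F)F)cnc3N3CCN(S(=O)(=O)c4ccc(N)nc4)CC3)ccc2o1`, is the next compound to be tested in this assay. Its change relative to compound 3 is 2-methyl-1,3-benzoxazol-5-yl in place of pyridin-3-yl on an aromatic carbon. Among the measured compounds shown here, the steps that bear on this position all involve small flat rings replacing a bromo, and none of them moved the number beyond the scatter. A larger two-ring group enters here, for which no comparison exists among the measured compounds. The expectation is therefore a modest step, if any, in this assay: a 1.3-fold higher number from compound 3 to compound 4 (0.11 log units; within the scatter). Compound 4 is expected to give about 22 mL.min-1.g-1, with a plausible range from 10 mL.min-1.g-1 to 50 mL.min-1.g-1.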

Compound 4, intrinsic clearance in microsomes: < 14 mL.min-1.g-1
Compound 4: only a limit was reported; the forecaster's own chance of this, stated with the estimate: 25%; middle value at least 1.5-fold (0.19 log units) away from the limit.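

The earlier compounds carried only a bromo or a single ring at this position, ortho to a large group, and compound 4 shows that a group of two fused rings can sit there and still return only a limit in this assay: the limit of < 14 mL.min-1.g-1 in this assay, at which 3 of the 4 values shown sit.

Among the compounds shown here, putting 2-methyl-1,3-benzoxazol-5-yl in place of pyridin-3-yl gives an at least 1.2-fold lower number from compound 3 to compound 4 (0.08 log units; that floor lies within the scatter), so this much larger group brings no readable rise in the number, and compound 3 remains the only compound with an actual value. The steps from compound 1 and from compound 2 to compound 4 join two limits and cannot be read.

On these data alone, the true values of compound 1, compound 2 and compound 4 remain unknown, so it is open whether these three differ from one another at all. Also open, as far as these compounds go, is how this assay would respond to a group of another kind at this position, such as an amine or a carboxylic acid.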